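Fluoro for methyl on the anilide ring of compound 1

The compounds below may be only part of what the source reports. "The series", "measured", "known", "first", "only" and "open" are said of these compounds alone.

Compound 1 `Cc1ccc(-c2nc3ccccc3o2)cc1NC(=O)c1cc([N+](=O)[O-])ccc1Cl` and compound 2 `O=C(Nc1ccc(O)c(-c2nc3ccccc3s2)c1)c1cc([N+](=O)[O-])ccc1Cl` share the nitro-chlorobenzamide part and have both been run in an ADME assay on HepG2 cells (Homo sapiens) for cytotoxicity, with a stated time of 72 h; on this read-out lower numbers stand for an effect already at smaller amounts and higher numbers for an effect only at larger amounts of compound. In this assay compound 1 gives only a limit, > 14000 nM, and no number. Compound 2 likewise gives only a limit in this assay, > 25000 nM. Both values are therefore limits, as seen in the limit of > 14000 nM in this assay, at which 1 of the 2 values shown sits, and (the limit of > 25000 nM in this assay, at which 1 of the 2 values shown sits), so compound 1 cannot be placed above or below compound 2 on the numbers shown.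

Compound 3 `O=C(Nc1cc(-c2nc3ccccc3o2)ccc1F)c1cc([N+](=O)[O-])ccc1Cl` is compound 1 with a single change: fluoro in place of methyl on an aromatic carbon. Among the measured compounds shown here, no measured step of this kind exists to lean on, and the only values at hand are limits. The step from compound 1 to compound 3 is expected to be small, a step that the limit leaves unreadable from compound 1 to compound 3, with no direction beyond the scatter. Compound 3 is therefore estimated at 20000 nM in this assay, within 10000 nM to 50000 nM, most likely again reported as a limit.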

Compound 3, half-maximal effective concentration: > 25000 nM
Compound 3: no number, only a limit (the forecaster's own chance of this, stated with the estimate: 80%); middle value at least 1.2-fold (0.09 log units) away from the limit.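

Among the compounds shown here, compound 1 and compound 3 each give only a limit in this assay, and no step between them can be read. The compounds shown leave open whether fluoro in place of methyl on an aromatic carbon changes the read-out at all, and where any true half-maximal concentration lies.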